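This account rests on a few compounds, and the source may have more. Where it says the series, first, only, none or still open, it means among the compounds named here.

Of the compounds shown here, three built on one shared core have been measured so far in a functional assay for inhibition, tested at 60 ug/mL; a higher number here means a stronger effect of the compound at the concentration tested, a lower number a weaker effect. Compound 1 `Cc1cc(O)c(C(C)C)cc1-c1cc(-c2ccccc2)c(C#N)c(=O)[nH]1` gives 34%. Compound 2 `COc1ccc(-c2cc(-c3cc(C(C)C)c(O)cc3C)[nH]c(=O)c2C#N)cc1`, which carries a methoxy in place of hydrogen on an aromatic carbon, gives 43%; the step of a number 9 percentage points higher from compound 1 to compound 2 (within the scatter) stays within the scatter. Compound 3 `Cc1cc(O)c(C(C)C)cc1-c1cc(-c2ccco2)c(C#N)c(=O)[nH]1` gives 55.2%, the highest of the three numbers: its nearest neighbour is compound 2, and compound 1 stands furthest from it. Both steps that end at compound 3 lie beyond the scatter, namely a number 21.2 percentage points higher from compound 1 to compound 3 (beyond the scatter) and a number 12.2 percentage points higher from compound 2 to compound 3 (beyond the scatter).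

Compound 4 `Cc1cc(O)c(C(C)C)cc1-c1cc(-c2ccc(N(C)C)cc2)c(C#N)c(=O)[nH]1` is the next compound to be tested in this assay. 4-(dimethylamino)phenyl in place of furan-2-yl on an aromatic carbon This change reverses the kind of move seen in the two steps that end at compound 3, where a furan-2-yl replaced a phenyl or a 4-methoxyphenyl and the numbers rose modestly. Compound 4, with its 4-(dimethylamino)phenyl, is closer in kind to compound 2 than to compound 1. The step from compound 3 to compound 4 is therefore expected to run downward, with an estimated size of a number 13.2 percentage points lower from compound 3 to compound 4 (beyond the scatter). Compound 4 is accordingly expected to give about 42% in this assay, in a range from 28% to 56%.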

Compound 4, a percentage reported as inhibition, at one concentration (the size of the read-out at that concentration, not a potency): 53%
The estimate for compound 4 lay 11 percentage points below the measured number; the measured number falls inside the stated range.
By their numbers in this assay, from the lowest: compounds 1, 2, 4 and 3 (each within the scatter of the next, the first and the last beyond it).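

Within the data shown here, at this position, opposite the ring nitrogen, a number 2.2 percentage points lower from compound 3 to compound 4 (within the scatter) means that in this assay furan-2-yl is no longer the only group to stand beyond the scatter from the phenyl of compound 1, since 4-(dimethylamino)phenyl, with a six-membered aromatic ring of carbon only, cannot be told apart from it. The a number 19 percentage points higher from compound 1 to compound 4 (beyond the scatter) shows that a substituent on that phenyl can carry the number beyond the scatter, which the methoxy of compound 2 did not do. Even so, a number 10 percentage points higher from compound 2 to compound 4 (within the scatter) leaves dimethylamino and methoxy unseparated, so the two substituted phenyl groups cannot be ranked against each other. Nothing at hand accounts for these steps.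

Going by these compounds, whether a primary amine or a carboxylic acid in place of the dimethylamino would stand with compound 4 or with compound 1 remains open, as does whether a thiophene would match furan-2-yl. Each number also comes from a single concentration, so how these compounds compare in potency is left unanswered.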